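The source may report more compounds than this note shows. Statements on the series, on what has been measured and on what is new or still open speak of the compounds shown alone.

Measured so far:
compound 1 `O=C(CN(c1nc(Cl)nc2[nH]cnc12)C1CC1)N[C@@H](CC(=O)OCc1ccccc1)C(=O)OCc1ccccc1` gives 34.7%
compound 2 `C[C@H](NC(=O)CN(c1nc(Cl)nc2[nH]cnc12)C1CC1)C(=O)O` gives 48.1%

Both numbers come from a functional assay on the whole organism (Tail, strain ICR) with Mus musculus as the target, in the tail flick test, with a stated time of 30 min, at a dose of 25 umol/kg by the oral route; on this read-out higher numbers stand for a stronger effect at the one dose given and lower numbers for a weaker effect. Going by the values given here, compound 1 stands lowest of the two; compound 2 lies higher by a gap beyond the scatter, but with no single-change step between them, this pair says nothing about a change on its own.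

Compound 3 `O=C(CN(c1nc(Cl)nc2[nH]cnc12)C1CC1)NCC(=O)OCc1ccccc1` differs from compound 1 as follows: hydrogen in place of (benzyloxycarbonyl)methyl on a saturated chain carbon bound to an amide-type nitrogen and a carbonyl carbon. Among the compounds with values here, no step of this kind has been measured in this assay, so no size can be read off. A small rise is expected, of a size near the scatter, roughly a number 6.3 percentage points higher from compound 1 to compound 3 (within the scatter). For compound 3 the estimate is 41%, within 22% to 60%.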

Compound 3, a percentage reported as activity, at one dose (the size of the read-out at that dose, not a potency): 18.7%
For compound 3 the middle estimate is 22.3 percentage points above the measured one, and the stated range ends above it.
By their numbers in this assay, from the lowest: compound 3; then compound 1; then compound 2.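

In this assay, going by these compounds alone, hydrogen in place of (benzyloxycarbonyl)methyl gives a number 16 percentage points lower from compound 1 to compound 3 (beyond the scatter), the first measured step at this position. On this pair, the substituent on this saturated chain carbon is not dispensable for the effect at the one dose given. Nothing measured here accounts for the drop.

Still open, as far as these compounds go, is whether the step follows the benzyl ester itself or any substituent on this carbon. An aminomethyl group or a longer alkyl chain in the same place would separate the two.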